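This account rests on a few compounds, and the source may have more. Where it says the series, first, only, none or still open, it means among the compounds named here.

Of the compounds shown here, two have been measured in a functional assay on CCRF-CEM cells (Homo sapiens) for inhibition, read by sulforhodamine B assay, with a stated time of 48 h; a lower number here means a stronger inhibitor of growth, a higher number a weaker inhibitor of growth. Compound 1 `O=C(Nc1cccc(-n2cc(-c3ccncc3)c(-c3ccc(Cl)c(O)c3)n2)c1)Nc1cccc(C(F)(F)F)c1` gives 1400 nM in this assay, and compound 2 `COc1cc(-c2nn(-c3cccc(NC(=O)Nc4cc(C(F)(F)F)cc(C(F)(F)F)c4)c3)cc2-c2ccncc2)ccc1Cl` gives 498 nM; compound 2 thus stands lowest of the two numbers, with compound 1 above it beyond the scatter. Compound 3 `O=C(Nc1cccc(-n2cc(-c3ccncc3)c(-c3ccc(Cl)c(O)c3)n2)c1)Nc1cc(C(F)(F)F)cc(C(F)(F)F)c1` is not yet measured. It differs from compound 2 by hydrogen in place of methyl on an oxygen on an aromatic ring, that is, methoxy to hydroxy on the 4-chloro-3-methoxyphenyl group. For the measured compounds named here, no measured pair isolates this change, so the direction is open; a step of modest size, estimated as a 1.4-fold higher number from compound 2 to compound 3 (0.15 log units; within the scatter), is expected. Compound 3 is therefore estimated at 700 nM, within 250 nM to 2000 nM.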

Compound 3, concentration for 50% growth inhibition: 789 nM
The estimate for compound 3 lay 1.1-fold (0.05 log units) below the measured number; the range from low to high includes it.
By their numbers in this assay, from the lowest: compounds 2, 3 and 1 (each within the scatter of the next, the first and the last beyond it).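

In this assay, methoxy to hydroxy on the 4-chloro-3-methoxyphenyl group gives a 1.6-fold higher number from compound 2 to compound 3 (0.20 log units; within the scatter), so hydrogen and methyl on this oxygen are not told apart in this series. With the hydroxy kept, trifluoromethyl in place of hydrogen on an aromatic carbon gives a 1.8-fold lower number from compound 1 to compound 3 (0.25 log units; within the scatter), and this step cannot be read as a real difference either. No measurement bearing on either step is available. Open, going by these compounds, is whether a longer chain on this oxygen, or an amine in place of the hydroxy, would give a step beyond the scatter.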